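The source may report more compounds than this note shows. Statements on the series, on what has been measured and on what is new or still open speak of the compounds shown alone.

Compound 2 `O=c1ccoc2cc(OCc3cn(Cc4ccccc4Cl)nn3)ccc12` was examined in an ADME assay on L02 cells (Homo sapiens) for cytotoxicity, read by MTT assay, with a stated time of 48 h; on this read-out lower numbers stand for stronger inhibition and higher numbers for weaker inhibition. In this assay compound 2 reaches only a limit of the assay, > 300000 nM, and no number. Compound 1 `Cc1cccc(Cn2cc(COc3ccc4c(=O)ccoc4c3)nn2)c1` is the single measured relative that differs from compound 2 in one place. In this assay compound 1 likewise stops at a limit of the assay, > 300000 nM. The step from compound 1 to compound 2, 2-chlorophenyl in place of 3-methylphenyl on a saturated chain carbon bound to an aromatic nitrogen, reads a step that the two limits leave unreadable from compound 1 to compound 2. Both measured values thus sit at the limit of > 300000 nM in this assay, at which 2 of the 2 values shown sit. Compound 3 `O=c1ccoc2cc(OCc3cn(Cc4ccccc4Br)nn3)ccc12` is not yet measured; it differs from compound 2 by bromo in place of chloro on an aromatic carbon, one halogen exchanged for another at a place ortho to a large group. Among the measured compounds shown here, the only measured step bears on this change merely by leaving no readable size, so no step beyond the scatter is expected in this assay in either direction. Compound 3 is therefore expected to rest at about 300000 nM, with a range from 150000 nM to 600000 nM. The step from compound 2 to compound 3 is estimated as a number no higher from compound 2 to compound 3 (the limit leaves the size open).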

Compound 3, half-maximal inhibitory concentration: > 300000 nM
Compound 3: only a limit was reported; the forecaster's own chance of this, stated with the estimate: 85%; the middle value sits exactly at the limit.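

In this assay compound 3 gives > 300000 nM, a limit of the assay and not a number. Among the compounds shown here, no step among compound 1, compound 2 and compound 3 can therefore be read: the limit of > 300000 nM in this assay, at which 3 of the 3 values shown sit. The compounds shown leave open where the true values of the three lie and whether these exchanges on the benzyl group alter them at all.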